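A few compounds are considered here, and "the series" means these few. Any claim that something is new, unique, unknown or untested is made for them only; others in the source may bear on it.

Compound 1 `O=C(CN1CCN(c2ccccn2)CC1)Nc1cccnc1` was measured in an assay on HEK293 cells for displacement of a labelled ligand from D(4) dopamine receptor (Homo sapiens), read by scintillation counting, with a stated time of 60 min (a higher number here means a weaker inhibitor, a lower number a stronger inhibitor), where compound 1 gives 6410 nM. Among the compounds with values here, of the two numbers so far it is the highest, and its nearest neighbour is compound 2 `O=C(CN1CCN(c2ccc(Cl)cn2)CC1)Nc1cccnc1`, which in this assay gives 5000 nM. Within the data shown here, the only step between measured compounds, a 1.3-fold lower number from compound 1 to compound 2 (0.11 log units; within the scatter), comes from a chloro in place of hydrogen on an aromatic carbon and lies within the scatter.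

Compound 3 `Cc1cccc(NC(=O)CN2CCN(c3ccccn3)CC2)c1` differs from compound 1 in a different place: 3-methylphenyl in place of pyridin-3-yl on an amide-type nitrogen. Among the measured compounds shown here, no measured step touches the amide-type nitrogen, so the step from compound 1 to compound 2 does not bear on this change, and the data give no direct guide to its size or direction. With nothing that speaks for a large effect, the expectation for this assay is a step of modest size, most likely towards a somewhat lower number, but one that could equally stay within the scatter; the expected step is a 1.8-fold lower number from compound 1 to compound 3 (0.26 log units; within the scatter). The estimated value for compound 3 in this assay is therefore 3500 nM, with a range from 800 nM to 15000 nM.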

Compound 3, inhibition constant: 212 nM
Compound 3: middle estimate off by 17-fold (1.22 log units), on the high side; measured number below the stated range.
By their numbers in this assay, from the lowest: compound 3; then compounds 2 and 1 (each within the scatter of the next).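

Within the data shown here, the amide-type nitrogen proves to be a position where the aromatic group matters greatly in this assay: 3-methylphenyl in place of pyridin-3-yl gives a large step (a 30-fold lower number from compound 1 to compound 3 (1.48 log units; beyond the scatter)), whereas the only earlier step, at another place, stayed within the scatter (a 1.3-fold lower number from compound 1 to compound 2 (0.11 log units; within the scatter)). This single step changes two things at once, since the hetero atom of the ring leaves and a methyl enters, so it cannot divide the gain between the loss of that ring nitrogen and the gain of the methyl. No measurement at hand bears on why the step is so large.

The compounds shown leave open whether plain phenyl would keep the lower number, which would separate the two parts of the change, and whether other groups on the ring, such as 3-chlorophenyl or 3-methoxyphenyl, would serve as well as 3-methylphenyl. They also leave open whether chloro in place of hydrogen, which made no clear difference on the core of compound 1, would behave the same way on the core of compound 3.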